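Adding a Third Chloro to an Aryl Propanamide

The source may report more compounds than this note shows. Statements on the series, on what has been measured and on what is new or still open speak of the compounds shown alone.

Compound 1 `CCC(=O)N(c1ccc(F)cc1)C1CCCC1N(C)C` gives 0.08 mg/kg in a functional assay on the whole organism for antagonist activity, with Mus musculus as the target; a higher number here means that more compound is needed for the effect, a lower number that less compound is needed. Compound 2 `CCC(=O)N(c1ccc(F)c(Cl)c1)C1CCCC1N(C)C` differs from compound 1 by the change (chloro in place of hydrogen on an aromatic carbon); in this assay compound 2 gives 2 mg/kg, and the step is a 25-fold higher number from compound 1 to compound 2 (1.40 log units; beyond the scatter). Compound 3 `CCC(=O)N(c1cc(Cl)cc(Cl)c1)C1CCCC1N(C)C` gives 5 mg/kg in this assay; how its core differs from the core of compound 1 is not broken down here. Compound 4 `CCC(=O)N(c1cc(Cl)c(Cl)c(Cl)c1)C1CCCC1N(C)C` is not yet measured and differs from compound 3 by chloro in place of hydrogen on an aromatic carbon. This is the same kind of change as from compound 1 to compound 2, though the place differs: there the entering chloro was ortho to a fluoro group and meta to a large group, here it is ortho to two chloro groups and para to a large group. The step to compound 4 is expected to be a 3.0-fold higher number from compound 3 to compound 4 (0.48 log units; beyond the scatter), smaller than the earlier one because compound 3 already gives 5 mg/kg, the highest number of the three. Compound 4 is expected to give 15 mg/kg in this assay.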

Compound 4, dose for half-maximal effect: 40 mg/kg
Compound 4: middle estimate off by 2.7-fold (0.43 log units), on the low side, within the range that was stated.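

In this assay the chloro in place of hydrogen on an aromatic carbon gives an 8.0-fold higher number from compound 3 to compound 4 (0.90 log units; beyond the scatter) and so moves the number in the same direction as on the core of compound 1, yet the size of the step does not carry over unchanged: the same change on two cores in this assay, a 25-fold higher number (1.40 log units; beyond the scatter) from compound 1 to compound 2 and an 8.0-fold higher number (0.90 log units; beyond the scatter) from compound 3 to compound 4, 3.1-fold (0.49 log units) apart, beyond the scatter of two such steps.
Two pairs make no rule, however, and the entering chloro in compound 4 also sits in a different place, ortho to two chloro groups and para to a large group, so these pairs do not show whether the core or the place accounts for the gap.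

The compounds shown leave open whether a bromo or a methoxy group in place of the entering chloro would follow the same course, and whether the step would hold with a longer chain in place of the propanamide.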